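Series notes: nitrile-bearing ethers on the acetophenone core

The compounds below may be only part of what the source reports. "The series", "measured", "known", "first", "only" and "open" are said of these compounds alone.

Compound 1 `CC(=O)c1ccc(OCCCCC#N)cc1O` carries the nitrile chain on the core without a further substituent and in an assay on isolated protein for binding affinity to leukotriene B4 receptor 1 (Homo sapiens), tested at 1 uM (on this read-out higher numbers stand for more inhibition at the one concentration tested (going by the name of the read-out) and lower numbers for less inhibition), compound 1 gives 0%. For the measured compounds named here, compound 2 `CCCCc1cc(C(C)=O)c(O)cc1OCCCCC#N` gives 13% in this assay, and the step of a number 13 percentage points higher from compound 1 to compound 2 (beyond the scatter) is the only measured step that is beyond the scatter. Compound 3 `COCc1cc(C(C)=O)c(O)cc1OCCCCCCC#N` gives 7% in this assay; its value lies within the scatter of both compound 2 and compound 1, so no order among the three can be drawn from it.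

Compound 4 `C=CCc1cc(C(C)=O)c(O)cc1OCCCCCCC#N` has not been measured. Relative to compound 3 the change is vinyl in place of methoxy on a saturated chain carbon bound to an aromatic carbon. Going by the values given here, no measured step bears directly on this change: the one step seen, butyl in place of hydrogen on an aromatic carbon, concerns another place on the core. The values of compounds 1, 2 and 3 all sit within one scatter band of each other, and there is no basis for a step beyond the scatter here. Compound 4 is therefore expected to give about 10% in this assay, with a range of 0% to 25%. The expected step of a number 3 percentage points higher from compound 3 to compound 4 (within the scatter) is estimated to stay within the scatter.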

Compound 4, a percentage reported as inhibition, at one concentration (the size of the read-out at that concentration, not a potency): 63%
Estimate against measurement, compound 4: 53 percentage points below, outside the stated range (above it).
By their numbers in this assay, from the lowest: compounds 1, 3 and 2 (each within the scatter of the next, the first and the last beyond it); then compound 4.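

For the compounds shown here, the step of a number 56 percentage points higher from compound 3 to compound 4 (beyond the scatter) in this assay shows that the group on a saturated chain carbon bound to an aromatic carbon can matter far more than the earlier compounds suggested. The group leaving and the group entering both count 2 heavy atoms, so the step comes with a change of kind and not of atom count: methoxy brings 1 hydrogen-bond acceptor, while vinyl brings none and adds 1 double bond outside aromatic rings. No measurement here gives a reason for the step.

The compounds shown do not separate the double bond from the loss of the oxygen, a question that a propyl group in place of allyl would address. As far as these compounds go, it also remains open how an amine or a carboxylic acid at this place would read out in this assay.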